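Propyl to ethyl: from compound 3 to compound 4

The source may hold more compounds than are shown below. What is called first, only, known or untested is meant among the compounds shown, and "the series" means these compounds.

Compound 3 `CCCN(Cc1cccs1)C(=O)COc1ccc(C)cc1` in an assay on HEK293 cells for agonist activity at transient receptor potential cation channel subfamily M member 8 (Homo sapiens), read by fluorescence and calcium flux, with a stated time of 15 min (a higher number here means that more compound is needed for the effect, a lower number that less compound is needed), gives 40 nM, the lowest of the two numbers obtained so far in this series. Compound 1 `CCN(Cc1ccoc1)C(=O)COc1ccc(C)cc1` in this assay gives 136 nM, a higher number than that of compound 3 by a step that lies beyond the scatter of repeated measurements. Compound 2 `CCN(Cc1ccncc1)C(=O)COc1ccc(C)cc1` in this assay is reported as "not active" (no number reported), so no number stands for it. Compound 1 and compound 2 differ from compound 3 in more than one place, so neither gives a step that isolates a single change.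

Compound 4 `CCN(Cc1cccs1)C(=O)COc1ccc(C)cc1` differs from compound 3 by hydrogen in place of methyl on a saturated chain carbon, two bonds along the chain from an amide-type nitrogen, which read one bond further out is propyl to ethyl. Among the compounds with values here, no pair of measured compounds covers this change on its own, so its size is not known from the data. A small step is expected, if anything toward a higher number, and likely within the scatter. Compound 4 is expected to give about 65 nM in this assay, with a range from 25 nM to 170 nM. This estimate means an expected step of a 1.6-fold higher number from compound 3 to compound 4 (0.21 log units; within the scatter).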

Compound 4, half-maximal effective concentration: 8 nM
For compound 4 the middle estimate is 8.1-fold (0.91 log units) above the measured one; the whole stated range lies above it.
By their numbers in this assay, from the lowest: compound 4; then compound 3; then compound 1.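

In this assay, within the data shown here, propyl to ethyl gives a 5.0-fold lower number from compound 3 to compound 4 (0.70 log units; beyond the scatter), the first step to isolate this chain, and it shows that the position on the saturated chain carbon, two bonds along the chain from the amide-type nitrogen, responds clearly to the loss of a single methyl. With ethyl held constant, thiophen-2-yl in place of furan-3-yl gives a 17-fold lower number from compound 1 to compound 4 (1.23 log units; beyond the scatter), the larger of the two steps, so the group on the saturated chain carbon bound to the amide-type nitrogen also matters strongly here. No measurement shown accounts for either step.

Going by these compounds, whether a methyl or a butyl chain on that nitrogen would continue the direction seen from propyl to ethyl remains open. Steps involving compound 2 cannot be read, since it has no number.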